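The source may report more compounds than this note shows. Statements on the series, on what has been measured and on what is new or still open speak of the compounds shown alone.

Compound 1 `O=C(O)Cc1sc(NCc2ccccc2)nc1-c1ccc(Cl)cc1`, compound 2 `O=C(O)Cc1sc(C(c2ccccc2)c2ccccc2)nc1-c1ccc(F)cc1` and compound 3 `NS(=O)(=O)c1ccc(-c2nc(C(c3ccc(F)cc3)c3ccc(F)cc3)sc2CC(=O)O)cc1` share a five-membered aromatic core carrying a carboxymethyl group, and they differ in what is attached around that core. In an in vitro functional assay on HEK285-7 cells for antagonist activity at prostaglandin D2 receptor 2 (Homo sapiens), read by BRET and beta-arrestin recruitment (on this read-out lower numbers stand for stronger inhibition and higher numbers for weaker inhibition), compound 1 gives 2300 nM. In this assay compound 2 gives 77 nM. Compound 3 gives only > 100000 nM, which is a limit of the assay and not a measured number. Compound 3 thus stands at the limit of > 100000 nM in this assay, at which 1 of the 3 values shown sits, so the numbers shown place it at the weak end of what the assay can report.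

Compound 4 `Nc1cc(-c2nc(C(c3ccc(F)cc3)c3ccc(F)cc3)sc2CC(=O)O)cc(F)n1` has not been measured. It is built from compound 3 by one change: 2-amino-6-fluoropyridin-4-yl in place of 4-sulfamoylphenyl on an aromatic carbon. No pair of measured compounds shows this change on its own, so nothing shown gives its size directly.

The expected step is an at least 33-fold lower number from compound 3 to compound 4 (1.52 log units; beyond the scatter), a move toward stronger inhibition that is estimated to go well beyond the usual scatter. Compound 4 is estimated at 3000 nM, with a range from 300 nM to 30000 nM, and there remains a fair chance that it, too, returns only a limit.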

Compound 4, half-maximal inhibitory concentration: 1400 nM
Beside the measured number, compound 4's estimate is 2.1-fold (0.33 log units) above it; low and high end bracket the measured number.
By their numbers in this assay, from the lowest: compound 2; then compounds 4 and 1 (each within the scatter of the next). At a limit, above all of these: compound 3.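

In this assay compound 3 gives > 100000 nM as a limit of the assay and not a number, so only a lower bound can be put on the size of the step: the limit of > 100000 nM in this assay, at which 1 of the 4 values shown sits. The change on this aromatic carbon, next to the ring nitrogen and next to the ring atom that bears a carboxymethyl group, gives an at least 71-fold lower number from compound 3 to compound 4 (1.85 log units; beyond the scatter) and shows that the group placed here can decide whether the assay reports a number at all. The leaving 4-sulfamoylphenyl and the entering 2-amino-6-fluoropyridin-4-yl have the same counts of hydrogen-bond donors and acceptors and no net charge, so those counts do not separate them, whereas the entering group has fewer heavy atoms and a hetero atom in its ring.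

The compounds shown leave open which part of the entering group goes with the step, since the amine, the fluorine and the ring nitrogen appear only together. On these data alone, it also remains open how a nitrile or a carboxylic acid on the same six-membered ring would read at this place.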